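From fluoro to dimethylamino on a shared core

A few compounds are considered here, and "the series" means these few. Any claim that something is new, unique, unknown or untested is made for them only; others in the source may bear on it.

Among the measured compounds shown here, in a functional assay on U-251 cells (Homo sapiens) for inhibition (on this read-out lower numbers stand for stronger inhibition of growth and higher numbers for weaker inhibition of growth), compound 1 (`COc1cccc(/C=C/c2ccc(S(N)(=O)=O)cc2)c1`) gives 5540 nM and compound 2 (`NS(=O)(=O)c1ccc(/C=C/c2ccc(F)cc2)cc1`) gives 7930 nM as two values within the usual scatter of each other, so compound 2 stands level with the only other number available. Compound 3 (`CN(C)c1ccc(/C=C/c2ccc(S(N)(=O)=O)cc2)cc1`) has dimethylamino in place of fluoro on an aromatic carbon. For the measured compounds named here, no measured pair yet shows what such a change does, so the estimate is only a modest step (a 2.0-fold lower number from compound 2 to compound 3 (0.30 log units; within the scatter)) towards stronger inhibition of growth, close to the edge of the scatter. The expected value for compound 3 is 4000 nM (estimated range 1000 nM to 14000 nM).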

Compound 3, concentration for 50% growth inhibition: 11200 nM
Compound 3: the middle estimate sits 2.8-fold (0.45 log units) below what was measured; measured number inside the range.
By their numbers in this assay, from the lowest: compounds 1, 2 and 3 (each within the scatter of the next, the first and the last beyond it).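

Exchanging fluoro for dimethylamino on an aromatic carbon, para to a large group, leaves the two compounds level in this assay (a 1.4-fold higher number from compound 2 to compound 3 (0.15 log units; within the scatter)). This first measured pair on the shared core shows a change at this position that stays within the scatter, even though the entering group brings a hydrogen-bond acceptor and the leaving group does not. One pair cannot show whether this holds for other groups.

On these data alone, whether a carboxylic acid or a chloro group at this position would give a value level with these remains open. Nothing measured here gives a reason for this result.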